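Hydroxamate swap on the benzoxazole analogue

This account rests on a few compounds, and the source may have more. Where it says the series, first, only, none or still open, it means among the compounds named here.

Compound 1 `CNC(=O)CCCCCCCn1nc(-c2cnc3[nH]ccc3c2)c2c(N)ncnc21` gives 6760 nM in a functional assay on HCT-116 cells (Homo sapiens) for inhibition, read by MTT assay, with a stated time of 72 h; a lower number here means a stronger inhibitor, a higher number a weaker inhibitor. Compound 2 `Nc1ncnc2c1c(-c1cnc3[nH]ccc3c1)nn2CCCCCCC(=O)NO` carries the change (hydroxycarbamoyl in place of (methylcarbamoyl)methyl on a saturated chain carbon, six bonds along the chain from an aromatic nitrogen); in this assay compound 2 gives 9860 nM, and the step is a 1.5-fold higher number from compound 1 to compound 2 (0.16 log units; within the scatter). Compound 3 `CNC(=O)CCCCCCCn1nc(-c2ccc3oc(N)nc3c2)c2c(N)ncnc21` differs from compound 1 by a group of 10 heavy atoms (7 carbon, 2 nitrogen, 1 oxygen; one five-membered aromatic ring with 2 hetero atoms, one six-membered aromatic ring of carbon only) in place of a group of 9 heavy atoms (7 carbon, 2 nitrogen; one five-membered aromatic ring with 1 hetero atom, one six-membered aromatic ring with 1 hetero atom), on an aromatic carbon; in this assay compound 3 gives 3150 nM, the step being a 2.1-fold lower number from compound 1 to compound 3 (0.33 log units; beyond the scatter), which leaves compound 3 with the lowest number of the three.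

Compound 4 `Nc1nc2cc(-c3nn(CCCCCCC(=O)NO)c4ncnc(N)c34)ccc2o1` stands to compound 3 as compound 2 stands to compound 1. The change hydroxycarbamoyl in place of (methylcarbamoyl)methyl on a saturated chain carbon, six bonds along the chain from an aromatic nitrogen is the same change, on the same place, with the two cores differing as described for compound 3 against compound 1.

For compound 4 the expected step is a 1.5-fold higher number from compound 3 to compound 4 (0.16 log units; within the scatter), set beside the earlier one, because the matched step a 1.5-fold higher number from compound 1 to compound 2 (0.16 log units; within the scatter) stayed within the scatter and nothing among the three measured compounds points to a different outcome on this core. Compound 4 is therefore estimated at 4600 nM in this assay, with a range from 2000 nM to 10500 nM.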

Compound 4, half-maximal inhibitory concentration: 5390 nM
Beside the measured number, compound 4's estimate is 1.2-fold (0.07 log units) below it, and the stated range covers the measured number.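

In this assay the hydroxycarbamoyl change on the benzoxazole-bearing core gives a 1.7-fold higher number from compound 3 to compound 4 (0.23 log units; within the scatter), and it carries over between the two cores without a detectable difference: the same change on two cores in this assay, a 1.5-fold higher number (0.16 log units; within the scatter) from compound 1 to compound 2 and a 1.7-fold higher number (0.23 log units; within the scatter) from compound 3 to compound 4, 1.2-fold (0.07 log units) apart, within the scatter of two such steps. Read the other way, the core change on the hydroxycarbamoyl chain gives a 1.8-fold lower number from compound 2 to compound 4 (0.26 log units; within the scatter), and it also carries over: the same change on two cores in this assay, a 2.1-fold lower number (0.33 log units; beyond the scatter) from compound 1 to compound 3 and a 1.8-fold lower number (0.26 log units; within the scatter) from compound 2 to compound 4, 1.2-fold (0.07 log units) apart, within the scatter of two such steps. This agreement rests on two pairs of small steps, so it does not show that the change would transfer to a third core, nor that the chain-end group matters in this cell read-out.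

Still open, going by these compounds, is how a carboxylic acid or an amine at the chain end would read in this assay. On these data alone, a shorter or longer chain on either core is also open.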